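Adding one methyl to compound 3

This account rests on a few compounds, and the source may have more. Where it says the series, first, only, none or still open, it means among the compounds named here.

Compound 1 `Cc1nn(C)c2nc(NNC(=O)Nc3cc(Cl)nc(Cl)c3)cc(-c3ccco3)c12`: > 100000 nM
Compound 2 `Cc1nn(C)c2nc(NNC(=O)Nc3cc(Cl)nc(Cl)c3)cc(C3CCCCC3)c12`: 22000 nM
Compound 3 `Cn1ncc2c(-c3ccc(F)cc3)cc(NNC(=O)Nc3cc(Cl)nc(Cl)c3)nc21`: 9150 nM

The value for compound 1 is a limit, not a number. In a functional assay on SW620/5-FU cells (Homo sapiens) for cytotoxicity, read by MTT assay, with a stated time of 48 h, in the presence of a further agent that is not named here (a lower number here means that less compound is needed, a higher number that more compound is needed for the effect), compound 3 has the lower of the two true numbers, and compound 2 sits higher, beyond the scatter. Compound 4 `Cc1nn(C)c2nc(NNC(=O)Nc3cc(Cl)nc(Cl)c3)cc(-c3ccc(F)cc3)c12` differs from compound 3 by one change: methyl in place of hydrogen on an aromatic carbon. Going by the values given here, the only measured step, an at least 4.5-fold lower number from compound 1 to compound 2 (0.65 log units; beyond the scatter), swaps a different group, so it shows that this number can move but does not size a methyl change. With no measured guide, the expected result is a 1.0-fold higher number from compound 3 to compound 4 (0.02 log units; within the scatter), with no shift beyond the scatter. Compound 4 is estimated at 9500 nM, with a range of 3500 nM to 26000 nM.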

Compound 4, half-maximal effective concentration: 17400 nM
The estimate for compound 4 lay 1.8-fold (0.26 log units) below the measured number; the measured number falls inside the stated range.
By their numbers in this assay, from the lowest: compounds 3, 4 and 2 (each within the scatter of the next, the first and the last beyond it). At a limit, above all of these: compound 1.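

On an aromatic carbon of the five-membered aromatic ring, methyl in place of hydrogen gives a 1.9-fold higher number from compound 3 to compound 4 (0.28 log units; within the scatter), so this position accepts that one added carbon without a shift beyond the scatter. With this methyl in place, 4-fluorophenyl in place of cyclohexyl gives a 1.3-fold lower number from compound 2 to compound 4 (0.10 log units; within the scatter), so this assay does not separate those two groups. Furan-2-yl stands apart, with 4-fluorophenyl in its place giving an at least 5.7-fold lower number from compound 1 to compound 4 (0.75 log units; beyond the scatter), a step that starts from a limit and not a number: the limit of > 100000 nM in this assay, at which 1 of the 4 values shown sits.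

As far as these compounds go, whether an ethyl chain, a methoxy group or an amine on the same carbon would also stay within the scatter remains open.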